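This account rests on a few compounds, and the source may have more. Where it says the series, first, only, none or still open, it means among the compounds named here.

Compound 1, `Cc1[nH]c2ccccc2c1C(c1ccccc1)c1cc2cc(C(C)(C)C)cc(C(C)(C)C)c2o1`, gives 72000 nM in a functional assay on SiHa cells (Homo sapiens) for cytotoxicity; a higher number here means a weaker inhibitor, a lower number a stronger inhibitor. Compound 2, `Cc1[nH]c2ccccc2c1C(c1ccc(Cl)cc1)c1cc2cc(C(C)(C)C)cc(C(C)(C)C)c2o1`, gives 35900 nM in this assay, and the step of a 2.0-fold lower number from compound 1 to compound 2 (0.30 log units; within the scatter) belongs to the change (chloro in place of hydrogen on an aromatic carbon). Compound 3, `Cc1c(C(c2ccccc2)c2cc3ccccc3o2)[nH]c2ccccc12`, reaches only a limit in this assay, > 100000 nM, as noted in the limit of > 100000 nM in this assay, at which 1 of the 3 values shown sits. How the core of compound 3 differs from the core of compound 1 is not broken down here. Compound 4, `Cc1c(C(c2ccc(Cl)cc2)c2cc3ccccc3o2)[nH]c2ccccc12`, carries the same change on the core of compound 3: chloro in place of hydrogen on an aromatic carbon. The step of a number no higher from compound 3 to compound 4 (the limit leaves the size open) expected from this change rests on the measured step of a 2.0-fold lower number from compound 1 to compound 2 (0.30 log units; within the scatter), though the limit for compound 3 leaves the starting point open. Compound 4 is therefore estimated at 100000 nM in this assay, between 40000 nM and 300000 nM, with a real chance that only a limit is reported again.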

Compound 4, half-maximal inhibitory concentration: 72500 nM
Compound 4: the middle estimate sits 1.4-fold (0.14 log units) above what was measured; the measured number falls inside the stated range.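

Carried to the core of compound 3, the change gives an at least 1.3-fold lower number from compound 3 to compound 4 (0.13 log units; that floor lies within the scatter) in this assay. Neither step is shown to lie beyond the scatter, and the size of the step on the core of compound 3 cannot be compared with the earlier one: the same change on two cores in this assay, a 2.0-fold lower number (0.30 log units; within the scatter) from compound 1 to compound 2 and an at least 1.3-fold lower number (0.13 log units; that floor lies within the scatter) from compound 3 to compound 4; the limit leaves it open whether they differ The series therefore does not show a real effect of the chloro group on either core or establish that the effect carries over unchanged, and compound 3 stands only at a limit: the limit of > 100000 nM in this assay, at which 1 of the 4 values shown sits.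

The compounds shown leave open how a methoxy group, an amine or a carboxylic acid in place of the chloro group would read on either core. They also leave open how the chloro group would read on a third core.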